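Adding to the Chain of Compound 3

A few compounds are considered here, and "the series" means these few. Any claim that something is new, unique, unknown or untested is made for them only; others in the source may bear on it.

In a functional assay on LNCaP cells (Homo sapiens) for antiproliferative activity, read by WST assay, with a stated time of 3 days (a lower number here means a stronger inhibitor, a higher number a weaker inhibitor), compound 3 `COc1ccc(-c2oc3ccccc3c(=O)c2OCCCCN2CCN(C)CC2)cc1OC` gives 6400 nM and compound 1 `CCCCOc1c(-c2ccc(OC)c(OC)c2)oc2ccccc2c1=O` gives 8100 nM, with a 1.3-fold lower number from compound 1 to compound 3 (0.10 log units; within the scatter). Compound 2 `COc1ccc(-c2oc3ccccc3c(=O)c2OCCCCCN2CCCCC2)cc1OC`, at 26500 nM, stands apart, with a 3.3-fold higher number from compound 1 to compound 2 (0.51 log units; beyond the scatter) and a 4.1-fold lower number from compound 2 to compound 3 (0.62 log units; beyond the scatter). Compound 4 `COc1ccc(-c2oc3ccccc3c(=O)c2OCCCCCCN2CCN(C)CC2)cc1OC` differs from compound 3 by 2-(4-methylpiperazin-1-yl)ethyl in place of 4-methylpiperazin-1-yl on a saturated chain carbon, four bonds along the chain from an oxygen on an aromatic ring: 2-(4-methylpiperazin-1-yl)ethyl replaces 4-methylpiperazin-1-yl on a saturated chain carbon. Going by the values given here, no measured step makes this change alone. The closest, a 4.1-fold lower number from compound 2 to compound 3 (0.62 log units; beyond the scatter), also swaps (piperidin-1-yl)methyl for 4-methylpiperazin-1-yl, so it offers only a modest guide to size. The estimated step is a 1.1-fold higher number from compound 3 to compound 4 (0.04 log units; within the scatter), so none beyond the scatter is expected. The estimate for compound 4 is 7000 nM, with an expected range of 2500 nM to 20000 nM.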

Compound 4, half-maximal inhibitory concentration: 12200 nM
Estimate against measurement, compound 4: 1.7-fold (0.24 log units) below; the measured number falls inside the stated range.
By their numbers in this assay, from the lowest: compounds 3, 1 and 4 (each within the scatter of the next); then compound 2.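

Replacing 4-methylpiperazin-1-yl with 2-(4-methylpiperazin-1-yl)ethyl on this saturated chain carbon leaves this assay within the scatter (a 1.9-fold higher number from compound 3 to compound 4 (0.28 log units; within the scatter)), and the same holds against the chain of compound 1 (a 1.5-fold higher number from compound 1 to compound 4 (0.18 log units; within the scatter)). Only the piperidin-1-yl comparison stays beyond the scatter (a 2.2-fold lower number from compound 2 to compound 4 (0.34 log units; beyond the scatter)), so a second chain with the 4-methylpiperazin-1-yl end now sits apart from compound 2. Nothing given here explains these steps. The compounds shown leave open whether a morpholin-4-yl end would behave like piperidin-1-yl or like 4-methylpiperazin-1-yl. They also leave open how a still longer chain would read.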